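The compounds below may be only part of what the source reports. "The series", "measured", "known", "first", "only" and "open" are said of these compounds alone.

Going by the values given here, compound 1 `NC1=NC2(CCOCC2)N(OCCCOc2cc(Cl)c(Cl)cc2Cl)C(N)=N1` stands at the highest number of the two compounds so far measured in a functional assay on HL-60 cells (Homo sapiens) for antiproliferative activity, read by MTT assay, with a stated time of 72 h; on this read-out lower numbers stand for stronger inhibition and higher numbers for weaker inhibition: compound 1 gives 2360 nM, whereas compound 2 `COc1ccc(OCCCON2C(N)=NC(N)=NC23CCSCC3)cc1` gives 500 nM, and that gap lies beyond the usual scatter. Compound 3 `Cc1cc(C)cc(OCCCON2C(N)=NC(N)=NC23CCOCC3)c1` has not yet been measured. It differs from compound 1 by 3,5-dimethylphenyl in place of 2,4,5-trichlorophenyl on an oxygen on a saturated carbon. Among the compounds with values here, no measured pair isolates this change, so the expected step is a 1.6-fold lower number from compound 1 to compound 3 (0.20 log units; within the scatter), modest and towards a lower number, and it may not reach beyond the scatter. Compound 3 is therefore estimated at 1500 nM, with a range from 500 nM to 4500 nM.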

Compound 3, half-maximal inhibitory concentration: 720 nM
Compound 3: middle estimate off by 2.1-fold (0.32 log units), on the high side, and the stated range covers the measured number.
By their numbers in this assay, from the lowest: compounds 2 and 3 (each within the scatter of the next); then compound 1.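

In this assay, going by these compounds alone, the replacement of 2,4,5-trichlorophenyl by 3,5-dimethylphenyl gives a 3.3-fold lower number from compound 1 to compound 3 (0.52 log units; beyond the scatter) and is the only change here isolated in a single place. It shows that the number responds to the aromatic group on this oxygen, even with no chlorine left on that group. Nothing measured accounts for the size or direction of this step. As far as these compounds go, it remains open whether a single methyl group, a fluorine or an amine on the aromatic ring would give a similar number. A longer chain between the two oxygens also remains untested in the compounds shown.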